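Cytotoxicity of carbonyl-substituent variants on the shared core

The source may hold more compounds than are shown below. What is called first, only, known or untested is meant among the compounds shown, and "the series" means these compounds.

Going by the values given here, the three measured members share the core of compound 1 `COc1ccc(-c2cnc(NC(=O)c3ccccc3F)n2C)cc1` and differ only in the group on the carbonyl carbon. In a toxicity assay on THP-1 cells (Homo sapiens) for inhibition (a lower number here means that less compound is tolerated, a higher number that more compound is tolerated), compound 1 gives > 100000 nM, which is a limit of the assay and not a number. Compound 2 `COc1ccc(-c2cnc(NC(=O)c3ccc(Br)cc3)n2C)cc1` carries a 4-bromophenyl group; in this assay compound 2 gives > 100000 nM, again a limit. Compound 3 `COc1ccc(-c2cnc(NC(=O)c3cccc(F)c3)n2C)cc1` carries a 3-fluorophenyl group; in this assay compound 3 gives > 100000 nM, also a limit. Compound 3 thus stands where the other two stand, at the limit of > 100000 nM in this assay, at which 3 of the 3 values shown sit. Among the compounds with values here, none of the measured steps can be sized: a step that the two limits leave unreadable from compound 1 to compound 2, a step that the two limits leave unreadable from compound 1 to compound 3 and a step that the two limits leave unreadable from compound 2 to compound 3 all run between two limits.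

Compound 4 `COc1ccc(-c2cnc(NC(=O)c3ccccc3Cl)n2C)cc1` is the next member. The change is 2-chlorophenyl in place of 3-fluorophenyl on a carbonyl carbon. The three steps bear on it only in that every exchange of the group on the carbonyl carbon has so far left the reading at the limit, so no step beyond the scatter is expected in this assay in either direction. Compound 4 is expected to give 150000 nM in this assay, with a range from 80000 nM to 400000 nM. The expected step is a step that the limit leaves unreadable from compound 3 to compound 4, and the reading is most likely to be another limit.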

Compound 4, half-maximal cytotoxic concentration: > 50000 nM
Compound 4: no number, only a limit; the forecaster's own chance of this, stated with the estimate: 90%; the middle value is on the limit's open side.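

In this assay compound 4 gives > 50000 nM, a limit and not a number. Its steps from compound 1, compound 2 and compound 3 all run between two limits and cannot be read. The compounds shown leave open whether any group on the carbonyl carbon gives a numerical reading in this assay, and how these four groups compare.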